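This account rests on a few compounds, and the source may have more. Where it says the series, first, only, none or still open, it means among the compounds named here.

In an ADME assay on HPLF cells (Homo sapiens) for cytotoxicity, with a stated time of 24 h (a lower number here means that less compound is tolerated, a higher number that more compound is tolerated), compound 3 `O=C1/C(=C/c2ccccc2)CCC/C1=C\c1ccc([N+](=O)[O-])cc1` gives 282000 nM, the higher of the two exact numbers in this small series. Compound 1 `O=C1/C(=C/c2ccc(Cl)cc2)CCC/C1=C\c1cccc([N+](=O)[O-])c1` gives the other, 38000 nM. Compound 2 `Cc1ccc(/C=C2\CCC/C(=C\c3cccc([N+](=O)[O-])c3)C2=O)cc1` gives > 400000 nM, which is a limit of the assay and not a number.

Compound 4 `CN(C)c1ccc(/C=C2\CCC/C(=C\c3ccc([N+](=O)[O-])cc3)C2=O)cc1` carries dimethylamino in place of hydrogen on an aromatic carbon, that is, dimethylamino in place of hydrogen on an aromatic carbon, para to a large group. For the measured compounds named here, the only measured step, an at least 10-fold higher number from compound 1 to compound 2 (1.02 log units; beyond the scatter), is large, with methyl in place of chloro on an aromatic carbon. It involves neither dimethylamino nor the same starting hydrogen, so it bears on the change only indirectly: a single exchange of this kind can move this assay well beyond the scatter. The direction is less certain, but a lower number is expected, since compound 1 at 38000 nM shows that the series can reach well down. The expected change is a 2.4-fold lower number from compound 3 to compound 4 (0.37 log units; beyond the scatter), of moderate size. For compound 4 the estimate is 120000 nM, with an expected range of 30000 nM to 400000 nM.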

Compound 4, half-maximal cytotoxic concentration: > 400000 nM
Compound 4: a limit, no number; the forecaster's own chance of this, stated with the estimate: 20%; at least 3.3-fold (0.52 log units) between middle value and limit.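

In this assay, dimethylamino in place of hydrogen on an aromatic carbon, para to a large group, gives an at least 1.4-fold higher number from compound 3 to compound 4 (0.15 log units; that floor lies within the scatter). This is the first exchange shown on the unsubstituted phenyl of compound 3, and the floor alone does not set compound 4 apart from compound 3 beyond the scatter, although it gives no sign of a lower number. Compound 4 gives > 400000 nM, which is a limit of the assay and not a number, so the size of the step stays unread: the limit of > 400000 nM in this assay, at which 2 of the 4 values shown sit.

As far as these compounds go, whether a primary amine or a carboxylic acid at this same place on the core of compound 3 would give an exact number remains open. From the compounds shown here alone, how far dimethylamino lies past the floor also remains open, and only an exact value for compound 4 could settle it.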